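The source may hold more compounds than are shown below. What is called first, only, known or untested is meant among the compounds shown, and "the series" means these compounds.

Measured so far in an assay for binding affinity to 17-beta-hydroxysteroid dehydrogenase type 1 (Homo sapiens), with a stated time of 20 min, tested at 1 uM; on this read-out lower numbers stand for less inhibition and higher numbers for more inhibition at the one concentration tested (going by the name of the read-out):

- compound 1 `O=[N+]([O-])c1ccc(-c2ccc3c(O)cccc3c2)cc1` gives 15%.
- compound 2 `COc1ccncc1-c1ccc2c(O)cccc2c1` gives < 10%, which is a limit of this assay rather than a number.
- compound 3 `Oc1cccc2cc(-c3ccoc3)ccc12` gives < 10%, again a limit of this assay.

For the measured compounds named here, compound 1 is thus the one member of the series with a number in this assay; the other two sit at the limit of < 10% in this assay, at which 2 of the 3 values shown sit. Going by the values given here, nothing connects the three by a single change, so no measured step exists from which to read the weight of a substituent on the shared core.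

Compound 4 `CNC(=O)c1ccc(-c2ccc3c(O)cccc3c2)cc1` is the next to be tested. It differs from compound 1 by methylcarbamoyl in place of nitro on an aromatic carbon. Among the compounds with values here, with no measured step available, the expectation is a change in this assay of no more than the usual scatter, in either direction, so that compound 4 stays close to compound 1: the step of no change at the digits printed from compound 1 to compound 4 (within the scatter) is the estimated one. For compound 4 the estimate in this assay is 15%, expected to fall between 5% and 30%.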

Compound 4, a percentage reported as inhibition, at one concentration (the size of the read-out at that concentration, not a potency): < 10%
Compound 4 gave a limit, no number; the forecaster's own chance of this, stated with the estimate: 35%; at least 5 percentage points between middle value and limit.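

In this assay, the series has its first step, at the aromatic carbon para to a large group, with methylcarbamoyl in place of nitro: a number at least 5 percentage points lower from compound 1 to compound 4 (that floor lies within the scatter). Compound 4 gives < 10%, which is a limit of this assay and not a number. Methylcarbamoyl thus brings no gain over nitro at this position, any loss remains unresolved, and the series now gathers at one value: the limit of < 10% in this assay, at which 3 of the 4 values shown sit.

On these data alone, whether another group on this carbon, such as a carboxylic acid, an amine or a nitrile, would give a number clear of that limit remains open. For the compounds shown here, how much this position matters compared with the rest of the shared core also remains open, as only one step has been read so far.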